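The source may report more compounds than this note shows. Statements on the series, on what has been measured and on what is new or still open speak of the compounds shown alone.

Measured so far in a functional assay on HEK293 cells for agonist activity at Free fatty acid receptor 1 (Homo sapiens), read by HTRF and inositol phosphate accumulation, with a stated time of 60 min; a higher number here means that more compound is needed for the effect, a lower number that less compound is needed:
compound 1 `CO[C@H]1C[C@H](Oc2cc(F)c(F)c(-c3ccc4c(c3)CC[C@H]([C@@H]3C[C@H]3C(=O)O)O4)c2)C1` — compound 1 gives > 10000 nM, a limit of the assay.
compound 2 `O=C(O)CC[C@H]1CCc2cc(-c3cc(OC4CCC4)ncc3F)ccc2O1` — compound 2 gives 2000 nM.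
compound 3 `O=C(O)CC[C@H]1CCc2cc(-c3cc(OC4CCC4)cc(Cl)c3F)ccc2O1` — compound 3 gives > 10000 nM, a limit of the assay.

Compound 1 stands at the limit of > 10000 nM in this assay, at which 2 of the 3 values shown sit, in this assay; it is a limit, so no number is known for it. Compound 3 sits at the same limit. Only compound 2 gives a number in this assay. Among the measured compounds shown here, no pair of measured compounds differs in one place, so no measured step guides the change.

Compound 4 `CO[C@H]1C[C@H](Oc2cc(F)c(F)c(-c3ccc4c(c3)CC[C@H](CCc3nnn[nH]3)O4)c2)C1` differs from compound 1 by 2-(1H-tetrazol-5-yl)ethyl in place of 2-carboxycyclopropyl on a saturated ring carbon, with the rest of compound 1 kept. With compound 1 known only as a limit, the size of the step cannot be set against a number; the expectation is that compound 4 stays close to that limit, any gain not established beyond the scatter. Compound 4 is expected at 8000 nM, in the range 2000 nM to 30000 nM. The step this estimate means is an at least 1.2-fold lower number from compound 1 to compound 4 (0.09 log units; that floor lies within the scatter).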

Compound 4, half-maximal effective concentration: > 10000 nM
Compound 4 ended at the assay's limit; the forecaster's own chance of this, stated with the estimate: 55%; middle value at least 1.2-fold (0.09 log units) from the limit.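

In this assay compound 4 gives > 10000 nM, a limit and not a number. Compound 1 stands at the same limit, so the step from compound 1 to compound 4 cannot be read. Left open is whether 2-(1H-tetrazol-5-yl)ethyl in place of 2-carboxycyclopropyl changes the value at all.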